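Fluoro for trifluoromethyl on the thiourea aniline

The source may report more compounds than this note shows. Statements on the series, on what has been measured and on what is new or still open speak of the compounds shown alone.

Three compounds of this series carry a sulfamoylphenyl group linked to a quinazoline bearing an anilino substituent, and all three have been measured in a functional assay on A-431 cells (Homo sapiens) for antiproliferative activity, read by MTT assay, with a stated time of 72 h; on this read-out higher numbers stand for weaker inhibition and lower numbers for stronger inhibition. Compound 1 `COc1ccccc1Nc1ncnc2cc(OC)c(OCCCCC(=O)Nc3ccc(S(N)(=O)=O)cc3)cc12` gives 24200 nM, and compound 2 `COc1cc2ncnc(Nc3ccc(C(F)(F)F)cc3)c2cc1OCCCCC(=O)Nc1ccc(S(N)(=O)=O)cc1` gives 16900 nM. Among the measured compounds shown here, the one step between measured compounds that differ in a single place, a 1.4-fold lower number from compound 1 to compound 2 (0.16 log units; within the scatter), exchanges the anilino aryl group and leaves the number essentially where it was. Compound 3 `NS(=O)(=O)c1ccc(NC(=S)Nc2ccc3ncnc(Nc4cccc(C(F)(F)F)c4)c3c2)cc1`, which replaces the ether-linked amide chain with a thiourea, gives 21700 nM; in this assay it stands second highest of the three numbers, with compound 1 nearest and compound 2 furthest, both gaps within the scatter.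

Compound 4 `NS(=O)(=O)c1ccc(NC(=S)Nc2ccc3ncnc(Nc4cccc(F)c4)c3c2)cc1` differs from compound 3 only in fluoro in place of trifluoromethyl on an aromatic carbon. For the measured compounds named here, no measured step changes this position on the thiourea scaffold; the only step on the anilino aryl group, from compound 1 to compound 2, was within the scatter, and the thiourea change from compound 2 to compound 3 likewise moved the number little. The expectation for a 1.0-fold higher number from compound 3 to compound 4 (0.01 log units; within the scatter) is therefore no step beyond the scatter. Compound 4 is estimated at 22000 nM, with a range from 8000 nM to 60000 nM.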

Compound 4, half-maximal inhibitory concentration: 30100 nM
Compound 4: the middle estimate sits 1.4-fold (0.14 log units) below what was measured; the measured number falls inside the stated range.
By their numbers in this assay, from the lowest: compounds 2, 3, 1 and 4 (each within the scatter of the next).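

On the thiourea scaffold, 3-fluorophenyl in place of 3-(trifluoromethyl)phenyl gives a 1.4-fold higher number from compound 3 to compound 4 (0.14 log units; within the scatter) in this assay and provides the first step read at this position of that scaffold. The earlier step on the anilino aryl group changed a different aryl group on the ether-linked amide scaffold, whereas this one shows that four heavy atoms can leave this aromatic carbon and one can enter without the number moving beyond the scatter. No measurement at hand bears on why the number stays within the scatter here.

Both measured steps in the series lie within the scatter, so the compounds shown give no substituent change that moves the number beyond it, and they do not show whether this aromatic carbon can affect the read-out at all on the thiourea scaffold. An amine, a carboxylic acid or a nitrile on the same aromatic carbon, or a carboxylic acid in place of the sulfamoyl group, would test whether either end of the thiourea compounds can shift the number beyond the scatter.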